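Replacing the pyridin-3-yl group of compound 1

A few compounds are considered here, and "the series" means these few. Any claim that something is new, unique, unknown or untested is made for them only; others in the source may bear on it.

Within the data shown here, in an ADME assay on microsomes from liver (Homo sapiens) for metabolic stability (on this read-out higher numbers stand for fast clearance and lower numbers for slow clearance), compound 1 `CCn1cnc2c(-c3ccc(F)c(-c4cccnc4)c3)cnnc21` gives 78 mL.min-1.g-1, the only exact number available. Compound 2 `CC(=O)N1CC(Oc2cc(-c3cnnc4c3ncn4C(C)C)ccc2F)C1` gives < 8 mL.min-1.g-1, which is a limit of the assay. Compound 3 `CCn1cnc2c(-c3ccc(F)c(Oc4cnc(C#N)nc4)c3)cnnc21` differs from compound 1 in one place: a group of 9 heavy atoms (5 carbon, 3 nitrogen, 1 oxygen; one six-membered aromatic ring with 2 hetero atoms) in place of a group of 6 heavy atoms (5 carbon, 1 nitrogen; one six-membered aromatic ring with 1 hetero atom), on an aromatic carbon. The new group sits on an aromatic carbon, ortho to a fluoro group. Among the measured compounds shown here, the one hint is compound 2, which also joins its group through an oxygen, at < 8 mL.min-1.g-1, so a fall beyond the scatter is expected in this assay. The expected step is a 2.6-fold lower number from compound 1 to compound 3 (0.41 log units; beyond the scatter). For compound 3 the estimate is 30 mL.min-1.g-1, with an expected range of 12 mL.min-1.g-1 to 70 mL.min-1.g-1.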

Compound 3, intrinsic clearance in microsomes: 49 mL.min-1.g-1
For compound 3 the middle estimate is 1.6-fold (0.21 log units) below the measured one, and the stated range covers the measured number.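

In this assay, putting the larger, oxygen-linked group with its nitrile in place of pyridin-3-yl, ortho to a fluoro group, gives a 1.6-fold lower number from compound 1 to compound 3 (0.20 log units; within the scatter). This position therefore accepts a quite different group without a change that can be told from ordinary assay noise. Compound 2 differs in more than one place and gives a limit rather than a number, so it offers no readable step here: the limit of < 8 mL.min-1.g-1 in this assay, at which 1 of the 3 values shown sits.

From the compounds shown here alone, whether the oxygen link, the ring or the nitrile matters most remains open. So does the effect of an amine or a methoxy group here.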